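Swapping the Amine Arm of Compound 2 for an Oxime Ether

The source may hold more compounds than are shown below. What is called first, only, known or untested is meant among the compounds shown, and "the series" means these compounds.

Of the compounds shown here, three sharing one core have been tested in a functional assay on SMMC-7721 cells (Homo sapiens) for antiproliferative activity, read by MTT assay, with a stated time of 48 h; a higher number here means a weaker inhibitor, a lower number a stronger inhibitor. Compound 1 `CC(C)=CCC[C@]1(C)/C=C/[C@@H](OC(=O)C=C(C)C)[C@](C)(O)/C=C/C(=O)/C(CCl)=C\C1` gives 840 nM, compound 2 `CC(C)=CCC[C@]1(C)/C=C/[C@@H](OC(=O)C=C(C)C)[C@](C)(O)/C=C/C(=O)/C(CN(C(C)C)C(C)C)=C\C1` gives 340 nM, and compound 3 `CC(C)=CCC[C@]1(C)/C=C/[C@@H](OC(=O)C=C(C)C)[C@](C)(O)/C=C/C(=O)/C(COC(=O)c2ccc([N+](=O)[O-])cc2)=C\C1` gives 2560 nM. Compound 2 therefore has the lowest number of the three, with a 2.5-fold lower number from compound 1 to compound 2 (0.39 log units; beyond the scatter) and a 7.5-fold higher number from compound 2 to compound 3 (0.88 log units; beyond the scatter). Compound 4 `CO/N=C/C1=C/C[C@](C)(CCC=C(C)C)/C=C/[C@@H](OC(=O)C=C(C)C)[C@](C)(O)/C=C/C1=O` differs from compound 2 at the same position: a group of 4 heavy atoms (2 carbon, 1 nitrogen, 1 oxygen; no ring) in place of a group of 8 heavy atoms (7 carbon, 1 nitrogen; no ring), on a double-bonded ring carbon. The two steps that changed this position, a 2.5-fold lower number from compound 1 to compound 2 (0.39 log units; beyond the scatter) and a 3.0-fold higher number from compound 1 to compound 3 (0.48 log units; beyond the scatter), were both modest, so a modest shift from compound 2 is expected, most likely upward. Compound 4 is expected to give about 900 nM, within 300 nM to 2700 nM, corresponding to a 2.6-fold higher number from compound 2 to compound 4 (0.42 log units; beyond the scatter).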

Compound 4, half-maximal inhibitory concentration: 3470 nM
The estimate for compound 4 lay 3.9-fold (0.59 log units) below the measured number; the measured number lies above the stated range.
By their numbers in this assay, from the lowest: compound 2; then compound 1; then compounds 3 and 4 (each within the scatter of the next).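

In this assay, the oxime ether gives the largest change yet seen at this position, a 10-fold higher number from compound 2 to compound 4 (1.01 log units; beyond the scatter), and it also compares poorly with the chloro arm, a 4.1-fold higher number from compound 1 to compound 4 (0.62 log units; beyond the scatter). Group size does not order these numbers: this arm is smaller than the (diisopropylamino)methyl group and larger than the chloro arm, yet its number is higher than both. Nothing measured here explains the rise.

On these data alone, it remains open whether the oxime ether itself or the missing saturated chain carbon matters more. A free oxime or a longer chain on the oxime oxygen could help separate the two.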